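Phenyl in place of dimethylamino on the shared core

This account rests on a few compounds, and the source may have more. Where it says the series, first, only, none or still open, it means among the compounds named here.

In an assay on isolated protein for inhibition of Leucine-rich repeat serine/threonine-protein kinase 2 variant G2019S (Homo sapiens), read by TR-FRET and LanthaScreen, with stated times of 50 min and 30 min, in the presence of a further agent that is not named here (on this read-out lower numbers stand for stronger inhibition and higher numbers for weaker inhibition), compound 3 `Cc1nn(CC(C)(C)O)cc1Nc1nc(N)c2c(C#N)c(N3CCC[C@H]3C)n(C)c2n1` gives 42 nM, compound 1 `Cc1cn(C)nc1Nc1cc2c(c(N)n1)c(C#N)c(N1CCC[C@H]1C)n2C` gives 1290 nM and compound 2 `CN(C)c1c(C#N)c2c(N)ncnc2n1C` gives 3760 nM. Compound 2 thus holds the highest number of the three; its gap to compound 1 and its far larger gap to compound 3 both lie beyond the usual scatter. Compounds 1 and 3 each carry further substituents on the shared core that compound 2 lacks, so their lower numbers say nothing direct about the change considered here.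

Compound 4 `Cn1c(-c2ccccc2)c(C#N)c2c(N)ncnc21` differs from compound 2 in one place: phenyl in place of dimethylamino on an aromatic carbon. Among the compounds with values here, no measured pair in the set shows a change of this kind, so no direction can be read from the numbers. Both compound 2 and compound 4 lack the added groups of compounds 1 and 3. The step from compound 2 to compound 4 is therefore expected to be small, a 1.3-fold lower number from compound 2 to compound 4 (0.10 log units; within the scatter), most likely within the scatter. Compound 4 is estimated at 3000 nM, with a range from 800 nM to 12000 nM.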

Compound 4, half-maximal inhibitory concentration: 483 nM
The estimate for compound 4 lay 6.2-fold (0.79 log units) above the measured number; measured number below the stated range.
By their numbers in this assay, from the lowest: compound 3; then compound 4; then compound 1; then compound 2.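

In this assay, phenyl in place of dimethylamino on the aromatic carbon gives a 7.8-fold lower number from compound 2 to compound 4 (0.89 log units; beyond the scatter), so the number at this position depends on the group it carries. A six-membered aromatic ring of carbon only is therefore compatible with a lower number here, even on a shared core without the further substituents of compounds 1 and 3. No measurement available here accounts for the step, which stands as an observation only.

The compounds shown leave open whether the aromatic ring itself matters or whether other groups would serve as well, such as a pyridine ring, a fluorophenyl ring or a butyl chain on the same carbon. On these data alone, it also remains open whether phenyl would give a similar step on the more substituted compounds 1 and 3.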